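Phenyl substituent change on the shared core, compound 2 to 3

The source may report more compounds than this note shows. Statements on the series, on what has been measured and on what is new or still open speak of the compounds shown alone.

Measured so far:
compound 1 `Cc1cc(NC(=O)Cn2nnc(-c3ccccc3F)n2)n(C2CCCCC2)n1` 88%
compound 2 `Cc1ccc(-c2nnn(CC(=O)Nc3cc(C)nn3C3CCCCC3)n2)cc1` 86%

Both compounds share one core and differ only in the aromatic group hanging from the five-membered aromatic ring with 4 nitrogen. In an assay on HEK293 cells for activation of Kir3.1/Kir3.2 (Homo sapiens), read by thallium flux (a higher number here means a larger maximal response, a lower number a smaller maximal response), compound 1 gives 88% and compound 2 gives 86%. Among the compounds with values here, the single step measured, a number 2 percentage points lower from compound 1 to compound 2 (within the scatter), lies within the scatter, so compound 2 sits level with compound 1 and no order between the two can be read.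

Compound 3 `COc1cccc(-c2nnn(CC(=O)Nc3cc(C)nn3C3CCCCC3)n2)c1` is the next member; its change from compound 2 is 3-methoxyphenyl in place of 4-methylphenyl on an aromatic carbon. Within the data shown here, the only step that bears on it is the earlier swap of one phenyl substituent for another, a number 2 percentage points lower from compound 1 to compound 2 (within the scatter), which produced nothing beyond the scatter. On that basis, compound 3 is expected to show a step of about a number 1 percentage points lower from compound 2 to compound 3 (within the scatter), that is no change beyond the scatter. Compound 3 is therefore estimated at 85%, within 70% to 98%.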

Compound 3, largest response reached (Emax), in percent of the reference or control that the assay uses: 76%
For compound 3 the middle estimate is 9 percentage points above the measured one; low and high end bracket the measured number.
By their numbers in this assay, from the lowest: compounds 3, 2 and 1 (each within the scatter of the next, the first and the last beyond it).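

In this assay, the step of a number 12 percentage points lower from compound 1 to compound 3 (beyond the scatter) is the only one beyond the scatter among the three compounds, so the group at this position on the shared core can bear on the maximal response. The direct change from 4-methylphenyl to 3-methoxyphenyl gives a number 10 percentage points lower from compound 2 to compound 3 (within the scatter) and so does not separate these two groups, which leaves compound 2 within the scatter of both neighbours. No measurement at hand accounts for the difference between 2-fluorophenyl and 3-methoxyphenyl.

Each swap here changes both the substituent and its place on the phenyl ring, so the compounds shown cannot tell these two changes apart. Also open, as far as these compounds go, is how the maximal response behaves with an amine or a carboxylic acid on that phenyl ring, or with an unsubstituted phenyl ring.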